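This account rests on a few compounds, and the source may have more. Where it says the series, first, only, none or still open, it means among the compounds named here.

Measured compounds in a functional assay on the whole organism (strain Wistar) for inhibition, with Rattus norvegicus as the target, read by paw edema, with a stated time of 2 h, at a dose of 10 mg/kg by the intraperitoneal route; a higher number here means more inhibition at the dose given (going by the name of the read-out), a lower number less inhibition:
- compound 1 `O=C(N/N=C/c1cccc(Cl)c1)c1cccnc1Nc1cccc(C(F)(F)F)c1` gives 63.5%
- compound 2 `O=C(N/N=C/c1ccc(O)c(O)c1)c1cccnc1Nc1cccc(C(F)(F)F)c1` gives 46.9%
- compound 3 `COc1ccc(/C=N/NC(=O)c2cccnc2Nc2cccc(C(F)(F)F)c2)cc1` gives 42.4%

Compound 3 holds the lowest of the three numbers; its gap to compound 2 lies within the scatter, while the gap to compound 1 lies beyond it, a number 21.1 percentage points lower from compound 1 to compound 3 (beyond the scatter). Compound 4 `O=C(N/N=C/c1ccncc1)c1cccnc1Nc1cccc(C(F)(F)F)c1` differs from compound 3 in one place, (pyridin-4-yl in place of 4-methoxyphenyl on a carbon with a double bond to nitrogen). Within the data shown here, no measured step makes this exact exchange. The steps that touch the same carbon are a number 16.6 percentage points lower from compound 1 to compound 2 (beyond the scatter) and a number 4.5 percentage points lower from compound 2 to compound 3 (within the scatter), with a number 21.1 percentage points lower from compound 1 to compound 3 (beyond the scatter) spanning both; all swaps of the aryl group on that carbon stayed within a modest band. Hence the expectation for a number 5.6 percentage points higher from compound 3 to compound 4 (within the scatter) is a step of no more than modest size in either direction, and compound 4 is estimated at 48% with a range from 30% to 66%.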

Compound 4, a percentage reported as inhibition, in the whole organism at one dose (the size of the read-out at that dose, not a potency): 65.2%
Beside the measured number, compound 4's estimate is 17.2 percentage points below it, and the stated range covers the measured number.
By their numbers in this assay, from the lowest: compounds 3 and 2 (each within the scatter of the next); then compounds 1 and 4 (each within the scatter of the next).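

Among these compounds, at this carbon with a double bond to nitrogen, the ring with a hetero atom shows the largest step so far in this assay, a number 22.8 percentage points higher from compound 3 to compound 4 (beyond the scatter), alongside a number 18.3 percentage points higher from compound 2 to compound 4 (beyond the scatter). With a number 1.7 percentage points higher from compound 1 to compound 4 (within the scatter), pyridin-4-yl and 3-chlorophenyl stand level, so the upper level at this position is not confined to a carbon-only aromatic ring or to a chlorine-bearing one. Nothing at hand accounts for these differences.

Still open, from the compounds shown here alone, is whether pyridin-3-yl or pyridin-2-yl would match pyridin-4-yl. Also open, going by these compounds, is how an aminophenyl or carboxyphenyl group would fare on this carbon.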